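Swapping methoxy for nitro on a shared core

A few compounds are considered here, and "the series" means these few. Any claim that something is new, unique, unknown or untested is made for them only; others in the source may bear on it.

In an ADME assay on Vero cells (Chlorocebus sabaeus) for cytotoxicity, read by resazurin assay, with a stated time of 72 h (a higher number here means a weaker inhibitor, a lower number a stronger inhibitor), compound 1 (`Cc1ccc(C(=O)CCN2CCN(c3ccc([N+](=O)[O-])cc3)CC2)cc1`) gives 235000 nM and compound 2 (`COc1ccc(N2CCN(CCC(=O)c3ccc(F)cc3)CC2)cc1`) gives 31900 nM as the lower of the two numbers, with a gap beyond the scatter. Compound 3 (`O=C(CCN1CCN(c2ccc([N+](=O)[O-])cc2)CC1)c1ccc(F)cc1`) has not yet been measured and differs from compound 2 in one place (nitro in place of methoxy on an aromatic carbon): nitro in place of methoxy on an aromatic carbon, para to a large group. Within the data shown here, no measured pair shows this change alone, so any step in this assay has to be judged indirectly. Compound 1 at 235000 nM also carries nitro, though it differs elsewhere as well, so a moderate upward step is expected, probably beyond the scatter. The estimated step is a 3.1-fold higher number from compound 2 to compound 3 (0.50 log units; beyond the scatter) on this reasoning. Compound 3 is expected at 100000 nM (estimated range 35000 nM to 280000 nM).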

Compound 3, half-maximal inhibitory concentration: 111000 nM
For compound 3 the middle estimate is 1.1-fold (0.05 log units) below the measured one, within the range that was stated.
By their numbers in this assay, from the lowest: compound 2; then compound 3; then compound 1.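

Among these compounds, with compound 3 in hand, nitro in place of methoxy on an aromatic carbon, para to a large group, can be read on its own for the first time. In this assay this single change gives a 3.5-fold higher number from compound 2 to compound 3 (0.54 log units; beyond the scatter) on the shared core, a modest move toward a weaker effect on the cells. A second single change, fluoro in place of methyl on an aromatic carbon, gives a 2.1-fold lower number from compound 1 to compound 3 (0.33 log units; beyond the scatter) and so moves the number the other way, and no supporting measurement accounts for either step.

From the compounds shown here alone, whether nitro in place of methoxy would give a step of similar size with methyl rather than fluoro on the other aromatic ring remains open. So does where other groups at the same position, such as an amine or a carboxylic acid, would fall relative to methoxy and nitro.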